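This account rests on a few compounds, and the source may have more. Where it says the series, first, only, none or still open, it means among the compounds named here.

Of the compounds shown here, three have so far been measured in a functional assay on isolated protein for agonist activity at Glucose-dependent insulinotropic receptor (Rattus norvegicus), read by HTRF and cAMP accumulation; a higher number here means a larger maximal response, a lower number a smaller maximal response. Compound 2 `CC(C)OC(=O)N1CCC(O[C@H]2CC[C@H](Oc3ccc(S(C)(=O)=O)nc3)CC2)CC1` stands highest, giving 125%; compound 3 `Cc1nc(S(C)(=O)=O)ccc1O[C@H]1CC[C@H](OC2CCN(C(=O)OC(C)C)CC2)CC1` gives 114%, and compound 1 `CC(C)(C)OC(=O)N1CCC(O[C@H]2CC[C@H](Oc3ccc(S(C)(=O)=O)cn3)CC2)CC1` gives 108%. Within the data shown here, the single one-point step, a number 11 percentage points lower from compound 2 to compound 3 (beyond the scatter), comes from methyl in place of hydrogen on an aromatic carbon. Compound 4 `CC(C)OC(=O)N1CCC(O[C@H]2CC[C@H](Oc3cnc(S(C)(=O)=O)cn3)CC2)CC1` remains to be measured; it differs from compound 2 by 5-(methylsulfonyl)pyrazin-2-yl in place of 6-(methylsulfonyl)pyridin-3-yl on an oxygen on a saturated carbon. Among the measured compounds shown here, no measured step alters the hetero atom count of that aromatic ring, so the step to compound 3 bears only loosely, as a sign that changes on this ring shift the maximal response modestly. Hence only a small step is expected, a number 10 percentage points lower from compound 2 to compound 4 (within the scatter), in either direction. Compound 4 is estimated at 115%, within 95% to 135%.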

Compound 4, largest response reached (Emax), in percent of the reference or control that the assay uses: 120%
The estimate for compound 4 lay 5 percentage points below the measured number; the measured number falls inside the stated range.
By their numbers in this assay, from the lowest: compounds 1, 3, 4 and 2 (each within the scatter of the next, the first and the last beyond it).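

The change to 5-(methylsulfonyl)pyrazin-2-yl on an oxygen on a saturated carbon gives a number 5 percentage points lower from compound 2 to compound 4 (within the scatter) in this assay. Among these compounds, a six-membered aromatic ring with 2 hetero atoms therefore holds the maximal response of the ring with 1 hetero atom, and this is the first change of ring hetero atom count. No evidence on why this response holds is available.

Open, as far as these compounds go, is whether the methylsulfonyl group itself can give way to a nitrile or a primary amide on either ring. Also open, from the compounds shown here alone, is how a plain phenyl ring would compare.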